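This account rests on a few compounds, and the source may have more. Where it says the series, first, only, none or still open, it means among the compounds named here.

Measured in an ADME assay for permeability, using PAMPA, with a stated time of 4 h, at pH 7.4; a lower number here means that the compound crosses the layer more slowly, a higher number that the compound crosses the layer faster:
Compound 1 `NCCCCN(C[C@@H]1Cc2ncccc2CN1)[C@H]1CCCc2cccnc21`: 7 nm/s
Compound 2 `CN(C[C@@H]1Cc2ncccc2CN1)[C@H]1CCCc2cccnc21`: 1000 nm/s
Compound 3 `NC/C=C/CN(C[C@H]1Cc2ncccc2CN1)[C@H]1CCCc2cccnc21`: 15 nm/s

Compound 3, at 15 nm/s, stands second of the three, far nearer compound 1 than compound 2. Compound 4 `CCN(CC)CCCCN(C[C@H]1Cc2ncccc2CN1)[C@H]1CCCc2cccnc21` differs from compound 3 by 3-(diethylamino)propyl in place of 3-aminoprop-1-en-1-yl on a saturated chain carbon bound to an amine nitrogen. Among the compounds with values here, the only measured step that bears on this is a 140-fold higher number from compound 1 to compound 2 (2.15 log units; beyond the scatter), in which the chain is replaced by hydrogen. Within the data shown here, compound 4 keeps a chain, and no measured step exchanges one chain for another, so a step of that size is not expected in this assay. A modest rise seems likelier, though this is uncertain. The expected step is a 2.0-fold higher number from compound 3 to compound 4 (0.30 log units; within the scatter). For compound 4 the estimated value is 30 nm/s. The expected range for compound 4 runs from 8 nm/s to 120 nm/s.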

Compound 4, apparent permeability: 240 nm/s
Estimate against measurement, compound 4: 8.0-fold (0.90 log units) below, outside the stated range (above it).
By their numbers in this assay, from the lowest: compound 1; then compound 3; then compound 4; then compound 2.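

In this assay there is a 16-fold higher number from compound 3 to compound 4 (1.20 log units; beyond the scatter) at this position, a saturated chain carbon bound to an amine nitrogen. A chain therefore need not be removed for a large step: exchanging 3-aminoprop-1-en-1-yl for 3-(diethylamino)propyl gives one on its own. No measurement at hand explains this step.

Going by these compounds, it remains open which part of the change carries the step, the diethylamino end or the loss of the double bond. Also open, on these data alone, is where a chain ending in a dimethylamino group, a pyrrolidine or a carboxylic acid would fall.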